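The source may report more compounds than this note shows. Statements on the series, on what has been measured and on what is new or still open speak of the compounds shown alone.

Measured compounds:
- compound 1, `c1ccc(CNC(c2ccc[nH]2)c2nnc(-c3ccccc3)o2)cc1`: 187000 nM
- compound 2, `COc1ccccc1CNC(c1ccc[nH]1)c1nnc(-c2ccccc2)o1`: 363000 nM

In a functional assay on A549 cells (Homo sapiens) for cytotoxicity, read by MTT assay, with a stated time of 24 h (a higher number here means a weaker inhibitor, a lower number a stronger inhibitor), compound 2 gives 363000 nM, the higher of the two numbers recorded; its nearest neighbour is compound 1, and the step of a 1.9-fold higher number from compound 1 to compound 2 (0.29 log units; within the scatter) lies within the scatter, so the two cannot be ordered on these figures alone.

Compound 3, `COc1ccc(CNC(c2ccc[nH]2)c2nnc(-c3ccccc3)o2)cc1`, differs from compound 2 by 4-methoxyphenyl in place of 2-methoxyphenyl on a saturated chain carbon bound to an amine nitrogen. Among the measured compounds shown here, the only measured step that bears on this change is a 1.9-fold higher number from compound 1 to compound 2 (0.29 log units; within the scatter), which concerns the introduction of the methoxy group rather than where it sits, and it did not exceed the scatter. For the measured compounds named here, no measured pair shows a shift of a methoxy group from one place on the ring to another, so there is no direct evidence that the new position should matter in this assay. Compound 3 is therefore expected to stay close to compound 2, with a step of a 1.2-fold lower number from compound 2 to compound 3 (0.08 log units; within the scatter) that remains within the usual scatter. The estimate for compound 3 in this assay is 300000 nM, expected to fall between 120000 nM and 750000 nM.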

Compound 3, half-maximal inhibitory concentration: 278000 nM
Beside the measured number, compound 3's estimate is 1.1-fold (0.03 log units) above it; the range from low to high includes it.
By their numbers in this assay, from the lowest: compounds 1, 3 and 2 (each within the scatter of the next).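

The pair now gives a direct reading of the change from 2-methoxyphenyl to 4-methoxyphenyl on a saturated chain carbon bound to an amine nitrogen: in this assay there is a 1.3-fold lower number from compound 2 to compound 3 (0.12 log units; within the scatter), so these figures do not separate the two placements of the methoxy group. The earlier step covered only the 2-methoxyphenyl compound, and the 4-methoxyphenyl compound now adds a 1.5-fold higher number from compound 1 to compound 3 (0.17 log units; within the scatter), so neither methoxy compound can be ordered against the unsubstituted benzyl compound on these figures. Nothing available explains these results or gives a reason for them.

All three compounds lie within the scatter of one another, so they leave open whether any change at this position can move the number beyond the scatter in this assay. As far as these compounds go, it also remains open whether an amine or a carboxylic acid on the aromatic ring in place of methoxy, or a longer chain in place of the benzyl link to the amine nitrogen, would give a clearer separation from compound 1 .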